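This account rests on a few compounds, and the source may have more. Where it says the series, first, only, none or still open, it means among the compounds named here.

Of the compounds shown here, three built on one shared core have been tested in a functional assay on SF-539 cells (Homo sapiens) for inhibition, read by sulforhodamine B assay, with a stated time of 48 h; on this read-out lower numbers stand for higher toxicity in this test and higher numbers for lower toxicity in this test. Compound 1, `O=C(Nc1cccc(-n2cc(-c3ccncc3)c(-c3ccc(Cl)c(O)c3)n2)c1)Nc1cccc(C(F)(F)F)c1`, reaches only a limit of the assay. In this assay compound 1 gives > 32500 nM. Compound 2, `COc1cc(-c2nn(-c3cccc(NC(=O)c4cccc(C(F)(F)F)c4)c3)cc2-c2ccncc2)ccc1Cl`, likewise gives only a limit. In this assay compound 2 gives > 50000 nM. Compound 3, `COc1cc(-c2nn(-c3cccc(NC(=O)Nc4ccc(Cl)c(Cl)c4)c3)cc2-c2ccncc2)ccc1Cl`, also yields only a limit. In this assay compound 3 gives > 50000 nM. For the measured compounds named here, the single step between measured neighbours, a step that the two limits leave unreadable from compound 2 to compound 3, has no readable size; both of its ends sit at the limit of > 50000 nM in this assay, at which 2 of the 3 values shown sit. Compound 3 therefore stands at the upper limit shared by two of the three values, while compound 1 sits at the limit of > 32500 nM in this assay, at which 1 of the 3 values shown sits, a lower limit that says nothing about any gap. Compound 4, `O=C(Nc1cccc(-n2cc(-c3ccncc3)c(-c3ccc(Cl)c(O)c3)n2)c1)Nc1ccc(Cl)c(Cl)c1`, differs from compound 3 by hydrogen in place of methyl on an oxygen on an aromatic ring. Going by the values given here, no measured step follows this change, and compound 1, which carries the hydroxy group, also shows only a limit, so no step beyond the scatter is expected. Compound 4 is therefore expected at 60000 nM, between 20000 nM and 200000 nM. The expected step is a step that the limit leaves unreadable from compound 3 to compound 4, essentially no change.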

Compound 4, concentration lethal to 50% of the cells: > 32500 nM
Compound 4 ended at the assay's limit; the forecaster's own chance of this, stated with the estimate: 80%; the middle value lies beyond the limit too.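

In this assay compound 4 gives only a limit, so no new step can be read from compound 3 to compound 4 or from compound 1 to compound 4. The compounds shown leave open whether methoxy to hydroxy, or either aryl change, alters the lethal concentration at all.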